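Chloro in Place of Methyl on the Amide of Compound 3

This account rests on a few compounds, and the source may have more. Where it says the series, first, only, none or still open, it means among the compounds named here.

The three measured compounds and their numbers:
compound 1, `CCNC(=O)c1cc(-c2ccc(F)cc2F)ccc1OC(C)=O`, in a functional assay on the whole organism (strain Kunming) for inhibition, with Mus musculus as the target, in the writhing test, at a dose of 40 mg/kg by the oral route (on this read-out higher numbers stand for more inhibition at the one dose given (going by the name of the read-out) and lower numbers for less inhibition), gives 23.9%;
compound 2, `CC(=O)Oc1ccc(-c2ccc(F)cc2F)cc1C(=O)NC1CCCCC1`, in this assay gives 15.6%;
compound 3, `CC(=O)Oc1ccc(-c2ccc(F)cc2F)cc1C(=O)Nc1ccc(C)cc1`, in this assay gives 31%.

Compound 3 holds the highest of the three numbers, but its lead is uneven: the step of a number 7.1 percentage points higher from compound 1 to compound 3 (within the scatter) lies within the scatter, whereas a number 15.4 percentage points higher from compound 2 to compound 3 (beyond the scatter) lies beyond it. The remaining step, a number 8.3 percentage points lower from compound 1 to compound 2 (within the scatter), is also within the scatter. All three measured steps exchange the group on the amide nitrogen; none of them touches a substituent on an aromatic ring.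

Compound 4, `CC(=O)Oc1ccc(-c2ccc(F)cc2F)cc1C(=O)Nc1ccc(Cl)cc1`, differs from compound 3 by chloro in place of methyl on an aromatic carbon. Among the measured compounds shown here, no measured step bears directly on this change, since every one of them varies the amide nitrogen substituent rather than a group on the aromatic ring of that substituent. With the 4-methylphenyl amide of compound 3 giving the highest number and no comparison available for chloro against methyl, the step of a number 1 percentage points lower from compound 3 to compound 4 (within the scatter) in this assay is what is expected, and this expected step should stay within the scatter. Compound 4 is therefore estimated at 30%, with a range from 15% to 45%.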

Compound 4, a percentage reported as inhibition, in the whole organism at one dose (the size of the read-out at that dose, not a potency): 29.9%
Beside the measured number, compound 4's estimate is 0.1 percentage points above it, within the range that was stated.
By their numbers in this assay, from the lowest: compounds 2, 1, 4 and 3 (each within the scatter of the next, the first and the last beyond it).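

At the aromatic carbon para to a large group, chloro in place of methyl gives a number 1.1 percentage points lower from compound 3 to compound 4 (within the scatter) in this assay, so this first change on the aromatic ring of the amide substituent does not separate the two groups in this read-out. Among the compounds shown here, the 4-chlorophenyl amide also stands against the other amide substituents much as the 4-methylphenyl amide did: 4-chlorophenyl in place of cyclohexyl gives a number 14.3 percentage points higher from compound 2 to compound 4 (beyond the scatter), while 4-chlorophenyl in place of ethyl gives a number 6 percentage points higher from compound 1 to compound 4 (within the scatter), so only the step from the cyclohexyl amide is a clear one. Nothing at hand accounts for these numbers.

The compounds shown leave open how a methoxy group, an amine or a carboxylic acid would read in place of chloro at this position, since methyl and chloro are the only two groups seen there. They also leave open whether a hydroxyl group in place of the acetyloxy group on the shared core would change the number for any of these amides, and each compound is seen at a single dose, which gives no potency.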